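The source may report more compounds than this note shows. Statements on the series, on what has been measured and on what is new or still open speak of the compounds shown alone.

Measured so far in a functional assay on the whole organism (strain Kunming) for inhibition, with Mus musculus as the target, with a stated time of 1 h, at a dose of 40 mg/kg by the oral route; on this read-out lower numbers stand for less inhibition and higher numbers for more inhibition at the one dose given (going by the name of the read-out):
- compound 1, `O=C(/C=C/c1ccccc1)c1ccc(N2CCN(c3cccc(Cl)c3Cl)CC2)cc1`: 30.7%
- compound 2, `COc1ccc(/C=C/C(=O)c2ccc(N3CCN(c4ccc(Cl)c(Cl)c4)CC3)cc2)cc1OC`: 63.5%
- compound 3, `COc1ccc(/C=C/C(=O)c2ccc(N3CCN(c4ccc(C)cc4C)CC3)cc2)cc1OC`: 48.5%

Compound 1 stands lowest of the three numbers; compound 3 is nearest, compound 2 furthest, and both gaps lie beyond the scatter. Going by the values given here, the one step that can be read within this set is a number 15 percentage points lower from compound 2 to compound 3 (beyond the scatter), a change of the aryl group on the amine nitrogen in the ring while the rest of the core is kept.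

Compound 4, `O=C(/C=C/c1ccccc1)c1ccc(N2CCN(S(=O)(=O)c3ccc(Cl)cc3)CC2)cc1`, is not yet measured. It differs from compound 1 in one place: (4-chlorophenyl)sulfonyl in place of 2,3-dichlorophenyl on an amine nitrogen in a ring.

Among the compounds with values here, only the step from compound 2 to compound 3 bears on this change, since it too alters the group on the amine nitrogen in the ring, and it was modest. Within the data shown here, no measured compound carries a sulfonyl group there, so nothing in this set tells the direction of a shift in this assay for such a replacement. The size of the step is therefore expected to be modest at most, in either direction, and a change within the scatter cannot be ruled out.

For compound 4 the expected result in this assay is 35%, with a range of 15% to 58%; this is an estimated step of a number 4.3 percentage points higher from compound 1 to compound 4 (within the scatter).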

Compound 4, a percentage reported as inhibition, in the whole organism at one dose (the size of the read-out at that dose, not a potency): 46.8%
Beside the measured number, compound 4's estimate is 11.8 percentage points below it; the range from low to high includes it.
By their numbers in this assay, from the lowest: compound 1; then compounds 4 and 3 (each within the scatter of the next); then compound 2.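

In this assay, the amine nitrogen in the ring of the core of compound 1 accepts a group attached through a sulfonyl as well as a directly attached aryl ring: (4-chlorophenyl)sulfonyl in place of 2,3-dichlorophenyl gives a number 16.1 percentage points higher from compound 1 to compound 4 (beyond the scatter) at the one dose tested. The earlier step at this position, a number 15 percentage points lower from compound 2 to compound 3 (beyond the scatter), exchanged one substituted phenyl for another on a different core, so it gave no reading for a change in the kind of link. The present change alters the link, the chlorine count and the chlorine placement in a single step, and the two hydrogen-bond acceptors of the sulfonyl enter with it, so the step cannot be assigned to any one of these, and no measurement available here gives a reason for it.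

Open, from the compounds shown here alone, is how (2,3-dichlorophenyl)sulfonyl or a 4-chlorobenzoyl group would read at this position, either of which would help separate the link from the chlorine pattern. Also open, going by these compounds, is whether (4-chlorophenyl)sulfonyl gives a step of similar direction on the core of compound 2.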